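The source may report more compounds than this note shows. Statements on the series, on what has been measured and on what is new or still open speak of the compounds shown alone.

Compound 1 `COC(=O)N1N=C(c2cccc(OC)c2)CC1c1cc(OC)c(OC)c(OC)c1` gives 1300 nM 
Compound 2 `COc1cccc(C2=NN(C(=O)OCc3ccccc3)C(c3cc(OC)c(OC)c(OC)c3)C2)c1` gives > 10000 nM (a limit) 
Compound 3 `COC(=O)N1N=C(c2cccc(O)c2)CC1c1cc(OC)c(OC)c(OC)c1` is not yet measured

Within the data shown here, in a functional assay on HT-29 cells (Homo sapiens) for antiproliferative activity, read by MTT assay, with a stated time of 48 h (a lower number here means a stronger inhibitor of growth, a higher number a weaker inhibitor of growth), compound 1 holds the only actual number so far. The entry for compound 2 (> 10000 nM) is a limit of the assay and not a number. Compound 3 has hydrogen in place of methyl on an oxygen on an aromatic ring, methoxy to hydroxy (hydrogen in place of methyl on an oxygen on an aromatic ring). Among the measured compounds shown here, the sole measured step (an at least 7.6-fold higher number from compound 1 to compound 2 (0.88 log units; beyond the scatter)) lies at a different place, so it gives no direct guide to size or direction here. No step beyond the scatter is therefore expected in this assay for this change, though with wide uncertainty. The expected step is small (a 1.2-fold higher number from compound 1 to compound 3 (0.06 log units; within the scatter)). The estimate for compound 3 is 1500 nM (expected range 400 nM to 6000 nM).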

Compound 3, concentration for 50% growth inhibition: 1350 nM
The estimate for compound 3 lay 1.1-fold (0.05 log units) above the measured number; the range from low to high includes it.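

In this assay, the exchange of 3-methoxyphenyl for 3-hydroxyphenyl stays within the scatter: a 1.0-fold higher number from compound 1 to compound 3 (0.02 log units; within the scatter). At this place, the methyl on the oxygen is therefore dispensable for the level of growth inhibition seen with compound 1, a point the earlier step, which lay at a different place, could not show. No evidence at hand bears on why this change leaves the number in place.

Going by these compounds, how an amine or an ethoxy group at this place would read in this assay remains open. On these data alone, whether the hydroxy group would be tolerated equally with a different group in place of the methyl ester also remains open.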